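This account rests on a few compounds, and the source may have more. Where it says the series, first, only, none or still open, it means among the compounds named here.

Compound 1 `O=C(O)c1csc([C@H]2CC[C@@H]3[C@@H](/C=C/COc4ccccc4)[C@H](O)C[C@@H]3O2)n1` and compound 2 `O=C(O)c1csc([C@H]2CC[C@@H]3[C@@H](COc4ccccc4F)[C@H](O)C[C@@H]3O2)n1` share a core and differ in the side chain carrying the phenoxy group. In a functional assay on CHO cells for agonist activity at prostaglandin E2 receptor EP2 subtype (Homo sapiens), read by HTRF and cAMP accumulation, with a stated time of 30 min (a lower number here means that less compound is needed, a higher number that more compound is needed for the effect), compound 1 gives 3.8 nM, while compound 2 gives 23 nM, the higher of the two numbers, beyond the scatter. Compound 3 `O=C(O)c1csc([C@H]2CC[C@@H]3[C@@H](CCOc4ccccc4)[C@H](O)C[C@@H]3O2)n1` has not yet been tested. The change from compound 2 to compound 3 is phenoxymethyl in place of 2-fluorophenoxy on a saturated chain carbon bound to a saturated ring carbon. Without a measured step of this kind, the expectation is a modest move to a lower number, so the expected step from compound 2 to compound 3 in this assay is a 2.3-fold lower number from compound 2 to compound 3 (0.36 log units; beyond the scatter). Compound 3 is estimated at 10 nM, within 3 nM to 40 nM.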

Compound 3, half-maximal effective concentration: 1.4 nM
For compound 3 the middle estimate is 7.1-fold (0.85 log units) above the measured one, outside the stated range (below it).
By their numbers in this assay, from the lowest: compound 3; then compound 1; then compound 2.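

In this assay, replacing 2-fluorophenoxy with phenoxymethyl on a saturated chain carbon bound to a saturated ring carbon gives a 16-fold lower number from compound 2 to compound 3 (1.22 log units; beyond the scatter). This side chain is therefore sensitive to a small edit: the swap keeps the number of heavy atoms and still shifts the value by a large step. Nothing measured here explains the size of this step. The change removes the fluorine and lengthens the chain together, so their contributions cannot be separated. A 2-(2-fluorophenoxy)ethyl group would separate them, while a 3-phenoxypropyl group would test a longer chain.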